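A few compounds are considered here, and "the series" means these few. Any claim that something is new, unique, unknown or untested is made for them only; others in the source may bear on it.

Measured so far in a functional assay on HGC-27 cells (Homo sapiens) for cytotoxicity, read by MTT assay, with a stated time of 72 h; on this read-out higher numbers stand for weaker inhibition and lower numbers for stronger inhibition:
compound 1 `CCCCCCCCNc1nc(SCc2ccc(C(F)(F)F)cc2)nc2ccccc12`: 13400 nM
compound 2 `FC(F)(F)c1ccc(CSc2nc(N3CCCCC3)c3ccccc3n2)cc1`: > 50000 nM, a limit, not a number
compound 3 `COc1ccccc1Nc1nc(SCc2ccc(C(F)(F)F)cc2)nc2ccccc12`: > 50000 nM, a limit, not a number

Compound 2 stands at the limit of this assay and has no number of its own. The same limit holds for compound 3, as the limit of > 50000 nM in this assay, at which 2 of the 3 values shown sit, shows. Compound 1 alone gives a number; the step from it is an at least 3.7-fold higher number from compound 1 to compound 2 (0.57 log units; beyond the scatter) and likewise an at least 3.7-fold higher number from compound 1 to compound 3 (0.57 log units; beyond the scatter). Compound 4 `COc1ccc(Nc2nc(SCc3ccc(C(F)(F)F)cc3)nc3ccccc23)c(OC)c1` is not yet measured. Its change from compound 2 is (2,4-dimethoxyphenyl)amino in place of piperidin-1-yl on an aromatic carbon. The step that bears most directly on it is a step that the two limits leave unreadable from compound 2 to compound 3, where two limits hide the size. The (2-methoxyphenyl)amino group of compound 3 is close to the group entering here. Compound 3 sits at the limit. No step beyond the scatter can be read from the data, so none is expected, and compound 4 is expected to stay at or near the limit, an expected step that the limit leaves unreadable from compound 2 to compound 4. The estimate for compound 4 is 60000 nM, within 25000 nM to 150000 nM.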

Compound 4, half-maximal inhibitory concentration: > 50000 nM
Compound 4: a limit, no number (the forecaster's own chance of this, stated with the estimate: 70%); the middle value is on the limit's open side.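

In this assay compound 4 gives > 50000 nM, which is a limit and not a number. Going by these compounds alone, with (2,4-dimethoxyphenyl)amino on the aromatic carbon next to the ring nitrogen, the one readable change is an at least 3.7-fold higher number from compound 1 to compound 4 (0.57 log units; beyond the scatter). The steps to compound 4 from compound 2 and compound 3 cannot be read, so the added methoxy shows no measurable effect, and a third group at this place joins the others at the limit: the limit of > 50000 nM in this assay, at which 3 of the 4 values shown sit.

Octylamino remains the only group here that gives a number, so it stays open how that number responds to a shorter chain such as butylamino or a longer one such as dodecylamino. Also open, from the compounds shown here alone, is whether a benzylamino group, or an aniline bearing a carboxylic acid, would come off the limit.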